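A Thiophene in Place of the Methylphenyl Arm

A few compounds are considered here, and "the series" means these few. Any claim that something is new, unique, unknown or untested is made for them only; others in the source may bear on it.

Compound 1 `COc1cc(-c2cc(-c3ccc(C)cc3)nc(-c3ccccc3)n2)cc(OC)c1OC`: > 25000 nM
Compound 2 `COc1cc(-c2cc(-c3ccc(O)cc3O)nc(-c3ccccc3)n2)cc(OC)c1OC`: 4960 nM

In a functional assay on HT-29 cells (Homo sapiens) for inhibition, read by MTT assay, with a stated time of 48 h (a higher number here means a weaker inhibitor, a lower number a stronger inhibitor), compound 1 gives no number, only a limit, > 25000 nM; it stands at the limit of > 25000 nM in this assay, at which 1 of the 2 values shown sits. Compound 2 gives 4960 nM in this assay. For the measured compounds named here, the only measured step is an at least 5.0-fold lower number from compound 1 to compound 2 (0.70 log units; beyond the scatter), and it rests on a limit, so its true size is not known.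

Compound 3 `COc1cc(-c2cc(-c3cccs3)nc(-c3ccccc3)n2)cc(OC)c1OC` has not been measured. It differs from compound 1 in this way: thiophen-2-yl in place of 4-methylphenyl on an aromatic carbon. The measured step concerns a different replacement at the same position and bears on compound 3 only in showing that the site tolerates change. Since the replacement in compound 3 brings no hydroxyl groups, the estimate for compound 3 in this assay is 20000 nM, with a range from 6000 nM to 60000 nM. The expected step is therefore an at least 1.2-fold lower number from compound 1 to compound 3 (0.09 log units; that floor lies within the scatter), and a limit rather than a number is roughly as likely as not.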

Compound 3, half-maximal inhibitory concentration: > 25000 nM
Compound 3: no number, only a limit; the forecaster's own chance of this, stated with the estimate: 50%; at least 1.2-fold (0.09 log units) between middle value and limit.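

Compound 3 gives only a limit in this assay, so thiophen-2-yl in place of 4-methylphenyl yields no readable number at this position, and the step between compound 1 and compound 3 cannot be read. The 2,4-dihydroxyphenyl group now stands apart from two different arms that carry no hydroxyl groups, and the replacement of that group by thiophen-2-yl gives an at least 5.0-fold higher number from compound 2 to compound 3 (0.70 log units; beyond the scatter). Among the three compounds, only one gives a number at this position, and the others share one limit: the limit of > 25000 nM in this assay, at which 2 of the 3 values shown sit.

As far as these compounds go, what remains open is whether thiophen-2-yl and 4-methylphenyl differ at all in this assay, and which part of the 2,4-dihydroxyphenyl group goes with the lower number. A phenyl arm with a single hydroxyl, or with an amine or a carboxylic acid in its place, would bear on that question.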